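Three-substituted aryl piperazine succinimides: fluoro to methyl swap

This account rests on a few compounds, and the source may have more. Where it says the series, first, only, none or still open, it means among the compounds named here.

Compound 1 `CCC(C(=O)N1CCN(c2cccc(F)c2)CC1)N1C(=O)CCC1=O` gives the lowest of the three numbers in hand. In a functional assay on the whole organism (strain Swiss) with Mus musculus as the target, in the maximal electroshock model, with a stated time of 0.25 h, at a dose of 100 mg/kg by the intraperitoneal route (on this read-out lower numbers stand for a weaker effect and higher numbers for a stronger effect at the one dose given), compound 1 gives 0%, while compound 2 `CC(C(=O)N1CCN(c2ccc(F)cc2)CC1)N1C(=O)CCC1=O` gives 75% and compound 3 `CC(C(=O)N1CCN(c2cccc(F)c2)CC1)N1C(=O)CCC1=O` gives 75%. For the measured compounds named here, the step of a number 75 percentage points higher from compound 1 to compound 3 (beyond the scatter) is the one large step in the set; the step of no change at the digits printed from compound 2 to compound 3 (within the scatter) shows that moving the fluoro around the aromatic ring left the number where it was.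

Compound 4 `CCC(C(=O)N1CCN(c2cccc(C)c2)CC1)N1C(=O)CCC1=O` keeps the ethyl chain of compound 1 and differs from it only in the aryl substituent: methyl in place of fluoro on an aromatic carbon. Going by the values given here, no measured step carries this particular exchange; the only aryl-ring step on record is the one from compound 2 to compound 3, which stayed within the scatter, and it concerns the fluoro position rather than its identity. The large step from compound 1 to compound 3 is unrelated to compound 4, whose chain is that of compound 1. The expectation is therefore anchored on compound 1, with a step of a number 10 percentage points higher from compound 1 to compound 4 (within the scatter) that is not expected to leave the scatter. Compound 4 is estimated at 10%, within a range from 0% to 40%.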

Compound 4, a percentage reported as activity, at one dose (the size of the read-out at that dose, not a potency): 50%
The estimate for compound 4 lay 40 percentage points below the measured number, and the stated range ends below it.
By their numbers in this assay, from the lowest: compound 1; then compound 4; then compounds 2 and 3 (each within the scatter of the next).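

In this assay, for the compounds shown here, the step of a number 50 percentage points higher from compound 1 to compound 4 (beyond the scatter) is the first large one recorded on the aromatic ring, for an exchange of 3-fluorophenyl to 3-methylphenyl that swaps one heavy atom for one heavy atom and leaves the counted hydrogen-bond donors, acceptors and charge as they were. The earlier aryl step no change at the digits printed from compound 2 to compound 3 (within the scatter) only moved the fluoro, so the identity of the group on this carbon can matter even though the fluoro's location made no difference in that one pair, which carries a different chain from compound 4. The reading for compound 1 cannot be tied to the ethyl chain alone, since compound 4 keeps that chain, and nothing measured here accounts for the step.

On these data alone, whether the gain extends to other groups on this carbon, such as chloro, methoxy or an amine, stays open, as does the effect of the same exchange on the chain of compound 3, which gives 75% with fluoro in place. A longer chain than the ethyl of compound 1 is also an open question for this series.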